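A few compounds are considered here, and "the series" means these few. Any claim that something is new, unique, unknown or untested is made for them only; others in the source may bear on it.

In a functional assay on MDA-MB-231 cells (Homo sapiens) for antiproliferative activity, read by MTT assay, with a stated time of 48 h (on this read-out lower numbers stand for stronger inhibition and higher numbers for weaker inhibition), compound 1 `C=CS(=O)(=O)N1CCN(c2nc(OC[C@H]3CCCN3C)nc3sc(-c4ccc(C#N)cc4)cc23)CC1` gives 3010 nM and compound 2 `C=CS(=O)(=O)N1CCN(c2nc(OC[C@H]3CCCN3C)nc3sc(-c4ccc(OC)nc4)cc23)CC1` gives 3560 nM, so compound 2 stands level with compound 1 within the scatter. Compound 3 `C=CS(=O)(=O)N1CCN(c2nc(OC[C@H]3CCCN3C)nc3sccc23)CC1` has hydrogen in place of 6-methoxypyridin-3-yl on an aromatic carbon. Going by the values given here, the only measured step, a 1.2-fold higher number from compound 1 to compound 2 (0.07 log units; within the scatter), swaps 4-cyanophenyl for 6-methoxypyridin-3-yl. Among the compounds with values here, it shows one group replacing another, and no measured compound lacks a group at this place, so the guide is weak. A moderate move to a higher number is expected, and the estimated change is a 2.2-fold higher number from compound 2 to compound 3 (0.35 log units; beyond the scatter). For compound 3 the estimated value is 8000 nM, within a range of 2500 nM to 25000 nM.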

Compound 3, half-maximal inhibitory concentration: > 50000 nM
Compound 3: a limit, no number (the forecaster's own chance of this, stated with the estimate: 15%); middle value at least 6.2-fold (0.79 log units) away from the limit.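

Compound 3 gives a limit and not a number: the limit of > 50000 nM in this assay, at which 1 of the 3 values shown sits. Hydrogen on the aromatic carbon next to the ring sulfur gives an at least 14-fold higher number from compound 2 to compound 3 (1.14 log units; beyond the scatter) and an at least 16-fold higher number from compound 1 to compound 3 (1.22 log units; beyond the scatter), whereas exchanging one aromatic ring for another gave only a 1.2-fold higher number from compound 1 to compound 2 (0.07 log units; within the scatter). In these compounds, then, what matters at this position is having an aromatic ring rather than hydrogen, more than which of the two rings it is. Still open, going by these compounds, is whether a group without a ring, such as methyl or a longer alkyl chain, would serve as well. On these data alone, how an amine on the phenyl ring would read also remains open.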